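A few compounds are considered here, and "the series" means these few. Any claim that something is new, unique, unknown or untested is made for them only; others in the source may bear on it.

Measured so far in a functional assay on SH-SY5Y cells (Homo sapiens) for cytotoxicity, read by MTT assay, with a stated time of 24 h; on this read-out higher numbers stand for weaker inhibition and lower numbers for stronger inhibition:
Compound 1 `C#CCNC1=CC(=O)c2cccc(OC)c2C1=O`: > 32000 nM (a limit)
Compound 2 `C#CCNC1=CC(=O)c2ccccc2C1=O`: > 64000 nM (a limit)

Neither compound has yet given a number. Going by these compounds, compound 2 stands only at its limit of > 64000 nM, and its exact value remains unknown. Compound 3 `C#CCN(C)C1=CC(=O)c2ccccc2C1=O` has not yet been measured. It carries methyl in place of hydrogen on an amine nitrogen.

Among the compounds with values here, only one measured step is available, a step that the two limits leave unreadable from compound 1 to compound 2, and it is hydrogen in place of methoxy on an aromatic carbon. That step lies at a different place from the new change, and its size cannot be read, so it offers no size to carry over. Within the data shown here, no measured step shows what this methyl does. The expectation therefore rests on compound 2 and its limit of > 64000 nM, and no step beyond the scatter is expected in this assay. The expected step is a number no higher from compound 2 to compound 3 (the limit leaves the size open). For compound 3 the estimated value is 64000 nM, with an expected range from 25000 nM to 130000 nM.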

Compound 3, half-maximal inhibitory concentration: 22000 nM
Compound 3: the middle estimate sits 2.9-fold (0.46 log units) above what was measured, and the stated range ends above it.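

In this assay, within the data shown here, methyl in place of hydrogen on an amine nitrogen gives an at least 2.9-fold lower number from compound 2 to compound 3 (0.46 log units; beyond the scatter), the only step in this set that can be read; the earlier step, hydrogen in place of methoxy on an aromatic carbon, cannot be read. This shows that the amine nitrogen, whose other neighbours are a double-bonded ring carbon and a saturated chain carbon, is a place where a single added methyl moves the read-out beyond the scatter, which the two earlier compounds could not show. The true size of this step stays open because compound 2 is known only through a limit, which marks the edge of what the assay reports: the limit of > 64000 nM in this assay, at which 1 of the 3 values shown sits.

The compounds shown leave open whether a group larger than methyl on the same nitrogen, such as ethyl or acetyl, would take the number further in the same direction. They also leave open what a longer chain in place of the propargyl group would do, and whether the methoxy group of compound 1 would alter the result once the nitrogen carries methyl.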